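The compounds below may be only part of what the source reports. "The series", "measured", "known", "first", "only" and "open" are said of these compounds alone.

Measured so far:

Compound 1, `CONC(=S)N/N=C1\C(=O)N(CN(C)C)c2ccc(F)cc21`: 560000 nM
Compound 2, `CCn1cc(C(=O)O)c(=O)c2cc(F)c(N3CCN(CN4C(=O)/C(=N\NC(=S)NOC)c5cc(Cl)ccc54)C(C)C3)c(F)c21`: 180000 nM
Compound 3, `CONC(=S)N/N=C1\C(=O)N(CN(C)C)c2ccc(Cl)cc21`: 552000 nM

All three numbers come from an ADME assay on MT4 cells (Homo sapiens) for cytotoxicity, read by spectrophotometry, with a stated time of 5 days; on this read-out lower numbers stand for higher toxicity in this test and higher numbers for lower toxicity in this test. Compound 3 and compound 1 share one small core and differ in a single place: fluoro in place of chloro on an aromatic carbon. This change made a step of a 1.0-fold higher number from compound 3 to compound 1 (0.01 log units; within the scatter), so in this assay the two compounds cannot be told apart. Compound 2 carries a much larger structure, and how its core differs from the core of compound 3 is not broken down here; what can be said is that compound 2 gives the lowest number of the three, and its gap to compound 3 and to compound 1 lies beyond the scatter.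

Compound 4, `CCn1cc(C(=O)O)c(=O)c2cc(F)c(N3CCN(CN4C(=O)/C(=N\NC(=S)NOC)c5cc(F)ccc54)C(C)C3)c(F)c21`, has not yet been tested. It relates to compound 2 as compound 1 relates to compound 3: fluoro in place of chloro on an aromatic carbon. The two changes occur at the same kind of position and are the same change. Since the same swap gave only a 1.0-fold higher number from compound 3 to compound 1 (0.01 log units; within the scatter) on the small core, the expectation is that the step from compound 2 to compound 4 will also be small, about a 1.1-fold higher number from compound 2 to compound 4 (0.02 log units; within the scatter). For compound 4 the estimate in this assay is therefore 190000 nM, with a plausible range from 90000 nM to 400000 nM, resting on the number of compound 2, 180000 nM, as the starting point.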

Compound 4, half-maximal cytotoxic concentration: 178000 nM
Compound 4: middle estimate off by 1.1-fold (0.03 log units), on the high side; measured number inside the range.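

In this assay, fluoro in place of chloro on an aromatic carbon of the larger structure gives a 1.0-fold lower number from compound 2 to compound 4 (0.00 log units; within the scatter), so this pair cannot be told apart. Set beside the same swap on the small core, the new step agrees with the earlier one: the same change on two cores in this assay, a 1.0-fold higher number (0.01 log units; within the scatter) from compound 3 to compound 1 and a 1.0-fold lower number (0.00 log units; within the scatter) from compound 2 to compound 4, 1.0-fold (0.01 log units) apart, within the scatter of two such steps. This shows that on both cores shown, the swap from chloro to fluoro made no difference that stands out from the scatter, so the result on one core was a fair guide to the result on the other; it does not show that the same would hold on a third core, in another test, or for any other swap, and two steps this small say nothing about whether a large step would carry over as well.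

The compounds shown carry only chloro or fluoro at this place on the ring, which leaves open what bromo, methyl or an amine would give there. From the compounds shown here alone, all four compounds also carry the same methoxy group, so what a longer chain such as ethoxy would give in its place remains open too.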